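The source may report more compounds than this note shows. Statements on the series, on what has been measured and on what is new or still open speak of the compounds shown alone.

In a functional assay on PC-3 cells (Homo sapiens) for inhibition, read by MTT assay, with a stated time of 48 h (a lower number here means a stronger inhibitor, a higher number a weaker inhibitor), compound 1 `COc1cc(-c2nnc(SCc3ccccc3)n2-c2ccc(N(C)C)cc2)cc(OC)c1OC` gives 55800 nM. Compound 2 `COc1ccc(CSc2nnc(-c3cc(OC)c(OC)c(OC)c3)n2-c2ccc(N(C)C)cc2)cc1` reads > 60000 nM, and that is a limit of the assay, not a number. Compound 3 `COc1cc(-c2nnc(SCC(=O)c3ccccc3)n2-c2ccc(N(C)C)cc2)cc(OC)c1OC` carries benzoyl in place of 4-methoxyphenyl on a saturated chain carbon bound to a sulfur. For the measured compounds named here, only one measured step bears on this change, and it touches the same part of the molecule: an at least 1.0-fold higher number from compound 1 to compound 2 (0.03 log units; that floor lies within the scatter). Going by these compounds, that step rests on (the limit of > 60000 nM in this assay, at which 1 of the 2 values shown sits), so its true size is unknown. Going by the values given here, no measured compound carries benzoyl, so the only guide is that compound 1, which also lacks the methoxy, gives 55800 nM. A weak value is therefore expected in this assay, with no step beyond the scatter. The estimated step is an at least 1.5-fold lower number from compound 2 to compound 3 (0.17 log units; that floor lies within the scatter). Compound 3 is expected at about 40000 nM, within a range of 12000 nM to 60000 nM.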

Compound 3, half-maximal inhibitory concentration: 38600 nM
Beside the measured number, compound 3's estimate is 1.0-fold (0.02 log units) above it; the range from low to high includes it.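

The benzoyl group of compound 3 and the phenyl of compound 1 cannot be told apart in this assay, with a 1.4-fold lower number from compound 1 to compound 3 (0.16 log units; within the scatter). A carbonyl at this place, on a saturated chain carbon bound to a sulfur, therefore gives a reading that stays within the scatter of the plain phenyl compound. The other comparison rests on a limit and not on a number, so an at least 1.5-fold lower number from compound 2 to compound 3 (0.19 log units; that floor lies within the scatter) is only a floor, and its true size is unknown: the limit of > 60000 nM in this assay, at which 1 of the 3 values shown sits.

Going by these compounds, all three compounds keep a six-membered aromatic ring of carbon only at this place, so what a quite different group would do here stays open. An amine, a carboxylic acid or a longer chain at this place remains untested in the compounds shown, as does a methoxy on the benzoyl ring.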